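The source may hold more compounds than are shown below. What is called first, only, known or untested is meant among the compounds shown, and "the series" means these compounds.

Among the measured compounds shown here, compound 3 `CCCn1c(=O)c2c(nc(Cc3ccccc3)n2C)n(Cc2ccco2)c1=O` occupies the second highest of the three numbers so far in an assay on HEK293 cells for displacement of a labelled ligand from adenosine receptor A2b (Homo sapiens); a lower number here means a stronger inhibitor, a higher number a weaker inhibitor; compound 3 gives 43.7 nM. For the measured compounds named here, compound 1 `CCCn1c(=O)c2[nH]c(Cc3ccccc3)nc2n(Cc2ccco2)c1=O` gives 117 nM, and the step of a 2.7-fold lower number from compound 1 to compound 3 (0.43 log units; beyond the scatter) is the only single-point change measured. Compound 2 `CCn1c(=O)c2c(nc(Cc3ccco3)n2C)n(Cc2ccco2)c1=O` gives 13.8 nM. Compound 4 `CCCn1c(=O)c2c(nc(Cc3ccco3)n2C)n(Cc2ccco2)c1=O` differs from compound 3 by furan-2-yl in place of phenyl on a saturated chain carbon bound to an aromatic carbon. Going by the values given here, no measured step isolates this change; compound 2 and compound 3 differ by this same swap together with a change in the chain on the other nitrogen, so their two values hint at a lower number but cannot be read as a clean step. Compound 4 is therefore expected to give a modest decrease, a 2.4-fold lower number from compound 3 to compound 4 (0.39 log units; beyond the scatter), to an estimated 18 nM (range 8 nM to 45 nM).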

Compound 4, inhibition constant: 19.1 nM
Estimate against measurement, compound 4: 1.1-fold (0.03 log units) below, and the stated range covers the measured number.
By their numbers in this assay, from the lowest: compounds 2 and 4 (each within the scatter of the next); then compound 3; then compound 1.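

Taken alone in this assay, furan-2-yl in place of phenyl on a saturated chain carbon bound to an aromatic carbon gives a 2.3-fold lower number from compound 3 to compound 4 (0.36 log units; beyond the scatter), so the swap now has a clean reading without a change in the chain on the other nitrogen. With furan-2-yl in place, methyl in place of hydrogen on a saturated chain carbon, two bonds along the chain from an aromatic nitrogen, gives a 1.4-fold higher number from compound 2 to compound 4 (0.14 log units; within the scatter), which does not separate the two chains. No evidence on the reason for either step is at hand. As far as these compounds go, whether thiophen-2-yl or pyridin-2-yl would serve in place of furan-2-yl remains open, as does the effect of a longer chain on that nitrogen.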